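Ester to Acid on a Biaryl Ester Core

The source may report more compounds than this note shows. Statements on the series, on what has been measured and on what is new or still open speak of the compounds shown alone.

Compounds measured so far:
compound 1, `CCOC(=O)c1cccc(-c2ccc(OCC)cc2)c1`, 87%
compound 2, `CCOC(=O)c1cccc(-c2ccc(OCC)c(N)c2)c1`, 59%

In an assay on COS-7 cells for inhibition of patatin-like phospholipase domain-containing protein 2 (Mus musculus), tested at 200 uM (a higher number here means more inhibition at the concentration tested (going by the name of the read-out), a lower number less inhibition), compound 1 gives 87%, the highest of the two numbers; its nearest neighbour is compound 2, and the step of a number 28 percentage points lower from compound 1 to compound 2 (beyond the scatter) is beyond the scatter. Compound 3, `CCOc1ccc(-c2cccc(C(=O)O)c2)cc1`, has not been measured. It differs from compound 1 in one place: hydrogen in place of ethyl on an oxygen next to a carbonyl group. The only measured step, a number 28 percentage points lower from compound 1 to compound 2 (beyond the scatter), concerns an amino group on an aromatic carbon and does not touch the ethoxycarbonyl group, so no step shown bears directly on the change from compound 1 to compound 3. The direction and size of the step in this assay are therefore uncertain. Compound 3 is estimated at 60%, between 20% and 95%, which corresponds to an expected step of a number 27 percentage points lower from compound 1 to compound 3 (beyond the scatter).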

Compound 3, a percentage reported as inhibition, at one concentration (the size of the read-out at that concentration, not a potency): 23%
Compound 3: middle estimate off by 37 percentage points, on the high side; the measured number falls inside the stated range.
By their numbers in this assay, from the lowest: compound 3; then compound 2; then compound 1.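

In this assay, the earlier step concerned only an amino group on an aromatic carbon, whereas this change acts on the ethoxycarbonyl group itself. Going from ethoxycarbonyl to carboxy gives a number 64 percentage points lower from compound 1 to compound 3 (beyond the scatter), which shows that this read-out is sensitive to what sits on an oxygen next to a carbonyl group, and that hydrogen cannot stand in for ethyl there on the core of compound 1. Nothing shown accounts for the size of this step.

The compounds shown leave open whether ethyl is specifically required or whether a methyl ester, a propyl ester or a longer chain on the same oxygen would do as well. They also leave open how a primary amide in place of the ethoxycarbonyl group would read in this assay.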